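Anilino replacing ethyl at the ring nitrogen neighbour

This account rests on a few compounds, and the source may have more. Where it says the series, first, only, none or still open, it means among the compounds named here.

Three amides on the shared core have numbers in an in vitro assay on HEK-tsA201 cells for antagonist activity at Neuronal acetylcholine receptor; alpha3/beta4 (Homo sapiens), read by fluorescence and calcium flux; a higher number here means a weaker inhibitor, a lower number a stronger inhibitor. Compound 1 `C=C(C)COc1ccc(C(=O)Nc2cccc(C)n2)cc1` gives 24700 nM. Compound 2 `C=CCOc1ccc(C(=O)Nc2cccc(CC)n2)cc1` gives 27400 nM. Compound 3 `CCCOc1ccc(C(=O)Nc2cccc(CC)n2)cc1` gives 29200 nM, and this number lies within the scatter of both other compounds, so no order among the three can be read from the assay. Among the measured compounds shown here, the only single-point step measured, a 1.1-fold higher number from compound 2 to compound 3 (0.03 log units; within the scatter), concerns the chain on the ether oxygen and not the group on the ring with the nitrogen.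

Compound 4 `CCCOc1ccc(C(=O)Nc2cccc(Nc3ccccc3)n2)cc1` is the next member. The change from compound 3 is anilino in place of ethyl on an aromatic carbon. For the measured compounds named here, no measured step touches this position: compound 1 and compound 2 carry methyl and ethyl there but also differ in the ether chain, and their two values show no gap beyond the scatter. The ethyl-for-vinyl step elsewhere on the core was flat, which says nothing about a seven-atom, ring-bearing substituent entering here. Going by the values given here, with no step bearing on it, the expectation for compound 4 is a number like that of compound 3, estimated at 29000 nM with a range of 8000 nM to 100000 nM, and the expected step of a 1.0-fold lower number from compound 3 to compound 4 (0.00 log units; within the scatter) is set close to none, held with a wide margin.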

Compound 4, half-maximal inhibitory concentration: > 100000 nM
Compound 4 ended at the assay's limit; the forecaster's own chance of this, stated with the estimate: 30%; at least 3.4-fold (0.53 log units) between middle value and limit.
By their numbers in this assay, from the lowest: compounds 1, 2 and 3 (each within the scatter of the next). At a limit, above all of these: compound 4.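

In this assay compound 4 stands at a limit of the assay and not at a number: the limit of > 100000 nM in this assay, at which 1 of the 4 values shown sits.

Among the compounds shown here, the step of an at least 3.4-fold higher number from compound 3 to compound 4 (0.53 log units; beyond the scatter) is the first measured change that lies beyond the scatter, and it falls on the aromatic carbon next to the ring nitrogen, a place that no earlier single-point step had touched. The position is therefore not indifferent to what it carries: here the flat picture among the first three compounds gives way when ethyl is exchanged for anilino, which brings in a six-membered aromatic ring of carbon only together with a hydrogen-bond donor and a hydrogen-bond acceptor.

This single step changes the ring and the linking nitrogen together, so it cannot say which of the two goes with the higher number; a phenyl group or a plain amino group at this place would separate them. Also open, as far as these compounds go, is whether any group here, such as a methoxy group or a longer chain, gives a lower number than ethyl does in compound 3.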